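Second Chlorine on the Aryl Amide of a Naphthyl Carbinol

The source may report more compounds than this note shows. Statements on the series, on what has been measured and on what is new or still open speak of the compounds shown alone.

Compound 1 `CC(C)CCC(=O)Nc1c(C(O)(C(F)(F)F)C(F)(F)F)ccc2ccccc12`: 49 nM
Compound 2 `O=C(Nc1c(C(O)(C(F)(F)F)C(F)(F)F)ccc2ccccc12)c1ccc(Cl)cc1`: 570 nM

In an assay on LtK cells with ATP-sensitive inward rectifier potassium channel 11 (Homo sapiens) as the target (on this read-out lower numbers stand for an effect already at smaller amounts and higher numbers for an effect only at larger amounts of compound), compound 2 has the higher of the two numbers; compound 1 gives 49 nM, and the step of a 12-fold higher number from compound 1 to compound 2 (1.07 log units; beyond the scatter) is large. Compound 3 `O=C(Nc1c(C(O)(C(F)(F)F)C(F)(F)F)ccc2ccccc12)c1cc(Cl)cc(Cl)c1` differs from compound 2 by 3,5-dichlorophenyl in place of 4-chlorophenyl on a carbonyl carbon. For the measured compounds named here, no measured step exchanges one chlorophenyl for another; the only step known, a 12-fold higher number from compound 1 to compound 2 (1.07 log units; beyond the scatter), swaps an alkyl chain for an aryl ring and so bears only loosely on this change. Compound 3 is therefore expected close to compound 2, a 1.1-fold lower number from compound 2 to compound 3 (0.06 log units; within the scatter), within the scatter. The estimate for compound 3 is 500 nM, with a range from 150 nM to 2000 nM.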

Compound 3, half-maximal effective concentration: 306 nM
Compound 3: the middle estimate sits 1.6-fold (0.21 log units) above what was measured; the measured number falls inside the stated range.
By their numbers in this assay, from the lowest: compound 1; then compounds 3 and 2 (each within the scatter of the next).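

On the carbonyl carbon, 3,5-dichlorophenyl and 4-chlorophenyl cannot be told apart in this assay, with a 1.9-fold lower number from compound 2 to compound 3 (0.27 log units; within the scatter). With a second aryl amide in hand, the aryl-for-alkyl swap again gives a number beyond the scatter, a 6.2-fold higher number from compound 1 to compound 3 (0.80 log units; beyond the scatter), and neither chlorinated ring reaches isopentyl here. Nothing available explains these numbers. As far as these compounds go, it remains open whether a longer chain in place of isopentyl would keep the number of compound 1, and whether an amine or a carboxylic acid on the aryl ring would separate from the chlorinated rings.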